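The source may hold more compounds than are shown below. What is called first, only, known or untested is meant among the compounds shown, and "the series" means these compounds.

Measured in an ADME assay on BJ cells (Homo sapiens), read by MTT assay, with a stated time of 72 h; on this read-out higher numbers stand for weaker inhibition and lower numbers for stronger inhibition:
- compound 1 `O=c1[nH]cnc2c1c(-c1ccccc1)cn2[C@@H]1O[C@H](CO)[C@@H](O)[C@H]1O`: > 100000 nM (a limit)
- compound 2 `Nc1nc(N)c2c(-c3ccco3)cn([C@@H]3O[C@H](CO)[C@@H](O)[C@H]3O)c2n1`: > 100000 nM (a limit)
- compound 3 `Cc1nc(N)c2c(-c3ccco3)cn([C@@H]3O[C@H](CO)[C@@H](O)[C@H]3O)c2n1`: > 100000 nM (a limit)

None of these entries is an exact number, and they share one ceiling: the limit of > 100000 nM in this assay, at which 3 of the 3 values shown sit. Compound 3 therefore has no exact place on the scale, and no order among the three can be read.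

The next compound is compound 4 `Cc1nc(N)c2c(I)cn([C@@H]3O[C@H](CO)[C@@H](O)[C@H]3O)c2n1`, which has iodo in place of furan-2-yl on an aromatic carbon. Among the compounds with values here, the only measured step is a step that the two limits leave unreadable from compound 2 to compound 3. It concerns a different change, methyl in place of amino, and its size cannot be read, so it offers no guide to the size of this step.

The expectation in this assay is thus only a loose one: compound 4 may well give another limit, while any readable number would mean stronger inhibition. The expected change is an at least 1.6-fold lower number from compound 3 to compound 4 (0.22 log units; that floor lies within the scatter). For compound 4 the estimated value is 60000 nM, with an expected range from 8000 nM to 100000 nM.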

Compound 4, half-maximal inhibitory concentration: 24600 nM
Estimate against measurement, compound 4: 2.4-fold (0.39 log units) above, within the range that was stated.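

In this assay, this change gives the first readable effect among the compounds shown: iodo in place of furan-2-yl brings an at least 4.0-fold lower number from compound 3 to compound 4 (0.60 log units; beyond the scatter). It shows that the read-out can respond to a change at this aromatic carbon, two ring bonds from the ring nitrogen, while the rest of compound 3 stays the same; the step between compound 2 and compound 3 cannot be read. The size printed for the new step is only a minimum, since compound 3 gives a limit and not an exact number, and it shares that ceiling with the earlier compounds: the limit of > 100000 nM in this assay, at which 3 of the 4 values shown sit.

Going by these compounds, it remains open whether the gain comes from the iodo itself or from the loss of the furan-2-yl ring. A chloro group, an amine or a longer chain at the same carbon could help separate the two.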